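The source may hold more compounds than are shown below. What is called first, only, known or untested is meant among the compounds shown, and "the series" means these compounds.

Compound 1, `O=C(COc1ccc2cc(/C=C3/SC(=O)NC3=O)ccc2c1)Nc1ccccn1` — in an assay on isolated protein for inhibition of histone deacetylase 8 (Homo sapiens), with a stated time of 1 h (a higher number here means a weaker inhibitor, a lower number a stronger inhibitor), compound 1 gives > 50000 nM, a limit of the assay rather than a number.
Compound 2, `O=C(COc1ccc2cc(/C=C3/SC(=O)NC3=O)ccc2c1)Nc1ccc(F)cc1F` — compound 2 gives > 50000 nM, also a limit of the assay.
Compound 3, `Cc1cc(Br)ccc1NC(=O)COc1ccc2cc(/C=C3/SC(=O)NC3=O)ccc2c1` — compound 3 gives 7400 nM.

Compound 1 therefore stands at the weak end of what has been measured: it reaches only the limit, and so does one of the two other compounds, a point noted in the limit of > 50000 nM in this assay, at which 2 of the 3 values shown sit. Only compound 3 gives a real number.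

Compound 4, `O=C(COc1ccc2cc(/C=C3/SC(=O)NC3=O)ccc2c1)Nc1c(F)cc(F)cc1Br`, has not yet been measured. It differs from compound 1 in one place: 2-bromo-4,6-difluorophenyl in place of pyridin-2-yl on an amide-type nitrogen. The change thus carries a halogen-bearing phenyl onto the amide nitrogen, as in both compound 2 and compound 3.

Going by the values given here, two measured steps bear on this. The step that the two limits leave unreadable from compound 1 to compound 2 cannot be read, since both ends sit at the limit. The step of an at least 6.7-fold lower number from compound 1 to compound 3 (0.82 log units; beyond the scatter), however, is at least modest and lies beyond the scatter, and the step of an at least 6.7-fold lower number from compound 2 to compound 3 (0.82 log units; beyond the scatter) is of the same size. The bromine of compound 3 is also present in compound 4, while the two fluorines match compound 2. An improvement over compound 1 is therefore expected, though a smaller one than for compound 3, with a real chance that the value again stays at the limit. The expected step is an at least 2.5-fold lower number from compound 1 to compound 4 (0.39 log units; beyond the scatter). Compound 4 is estimated at 20000 nM, within a range from 6000 nM to 60000 nM.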

Compound 4, half-maximal inhibitory concentration: > 50000 nM
Compound 4 gave a limit, no number; the forecaster's own chance of this, stated with the estimate: 35%; at least 2.5-fold (0.39 log units) between middle value and limit.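

Going by these compounds alone, the one step that can be read here is an at least 6.7-fold higher number from compound 3 to compound 4 (0.82 log units; beyond the scatter) in this assay. It shows that a bromine on the phenyl ring is not enough on its own: compound 4 carries one, as compound 3 does, yet it does not keep the measurable inhibition of compound 3. The steps from compound 1 and from compound 2 to compound 4 cannot be read, as both ends of each are limits, so adding bromo to compound 2 brings no visible gain, and at this amide-type nitrogen only the 4-bromo-2-methylphenyl of compound 3 has so far lifted a compound off the limit: the limit of > 50000 nM in this assay, at which 3 of the 4 values shown sit.

From the compounds shown here alone, what remains open is which part of the 4-bromo-2-methylphenyl group matters, as compound 3 and compound 4 differ in the methyl, the fluorines and the place of the bromine all at once. A plain 2-methylphenyl or 4-bromophenyl on the same nitrogen would help to separate these, and a 4-chloro-2-methylphenyl would test whether the bromine can be replaced by another halogen.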